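One Amine Swap on a Shared Core

The source may report more compounds than this note shows. Statements on the series, on what has been measured and on what is new or still open speak of the compounds shown alone.

Of the compounds shown here, two built on a shared core have been tested in an assay on HEK293 cells for inhibition of Steryl-sulfatase (Homo sapiens), tested at 1 uM; on this read-out lower numbers stand for a weaker effect and higher numbers for a stronger effect at the one concentration tested. Compound 1 `NS(=O)(=O)Oc1ccc2c(c1)CN(C(=O)c1cccc(N3CCN(c4ncccn4)CC3)c1)CC2` gives 24.4%. Compound 2 `CC(C)CCN(CCC(C)C)c1cccc(C(=O)N2CCc3ccc(OS(N)(=O)=O)cc3C2)c1` gives 75.9%, the higher of the two numbers, and its gap to compound 1 lies beyond the usual scatter. Compound 3 `CCN(Cc1cccnc1)c1cccc(C(=O)N2CCc3ccc(OS(N)(=O)=O)cc3C2)c1` is not yet measured; it differs from compound 2 by ethyl((pyridin-3-yl)methyl)amino in place of diisopentylamino on an aromatic carbon. Among the measured compounds shown here, no measured pair isolates this change, so the expectation rests only on these two values. The estimate means an expected downward step of a number 27.9 percentage points lower from compound 2 to compound 3 (beyond the scatter). Compound 3 is estimated at 48%, with a range from 25% to 72%.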

Compound 3, a percentage reported as inhibition, at one concentration (the size of the read-out at that concentration, not a potency): 33.5%
Compound 3: the middle estimate sits 14.5 percentage points above what was measured; the range from low to high includes it.
By their numbers in this assay, from the lowest: compounds 1 and 3 (each within the scatter of the next); then compound 2.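

On this aromatic carbon the amine matters a great deal: in this assay, placing ethyl((pyridin-3-yl)methyl)amino where diisopentylamino stood gives a number 42.4 percentage points lower from compound 2 to compound 3 (beyond the scatter) on an unchanged core. Compound 3 falls within the usual scatter of compound 1, so among these three amines, only the ringless diisopentylamino of compound 2 stands apart. No measurement shown here explains the drop.

From the compounds shown here alone, it remains open whether the loss follows the pyridine ring or the loss of the isopentyl chains. Diethylamino and benzyl(ethyl)amino groups at this position could help tell those two apart.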